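The compounds below may be only part of what the source reports. "The series", "measured", "known", "first", "only" and "open" are said of these compounds alone.

Measured so far:
compound 1 `O=C1NC(COCc2cc(C(F)(F)F)cc(C(F)(F)F)c2)(c2ccc(F)cc2)CN1C1CCNCC1` — 0.9 nM
compound 2 `O=C1NC[C@@](COCc2cc(C(F)(F)F)cc(C(F)(F)F)c2)(c2ccccc2)N1` — 6 nM
compound 3 `O=C1NC(COCc2cc(C(F)(F)F)cc(C(F)(F)F)c2)(c2ccc(F)cc2)CN1C1CCOCC1` — 6.3 nM

In an assay on CHO cells for displacement of a labelled ligand from Substance-P receptor (Homo sapiens) (on this read-out higher numbers stand for weaker inhibition and lower numbers for stronger inhibition), compound 3 gives the highest of the three numbers. Compound 2 is the nearest to it, and the two lie within the scatter of each other, so no order between them is claimed. Compound 1 is the furthest, separated by a 7.0-fold higher number from compound 1 to compound 3 (0.85 log units; beyond the scatter), a gap beyond the scatter.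

Compound 4 `CN1CCC(N2CC(COCc3cc(C(F)(F)F)cc(C(F)(F)F)c3)(c3ccc(F)cc3)NC2=O)CC1` differs from compound 3 by 1-methylpiperidin-4-yl in place of oxan-4-yl on an amide-type nitrogen in a ring. Among the compounds with values here, the one measured step that bears on this change is a 7.0-fold higher number from compound 1 to compound 3 (0.85 log units; beyond the scatter), which is the same exchange run the other way, except that the ring nitrogen entering here carries a methyl. Compound 2 carries neither group and gives no guidance on the change itself. On that basis the expected step of a 4.2-fold lower number from compound 3 to compound 4 (0.62 log units; beyond the scatter) runs towards a lower number in this assay, of roughly the size of the measured step in reverse. What the added methyl does to that outcome cannot be read from the present compounds, so the range is kept wide. Compound 4 is therefore estimated at 1.5 nM, with a range from 0.5 nM to 5 nM.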

Compound 4, inhibition constant: 0.4 nM
Compound 4: the middle estimate sits 3.8-fold (0.57 log units) above what was measured; the whole stated range lies above it.
By their numbers in this assay, from the lowest: compound 4; then compound 1; then compounds 2 and 3 (each within the scatter of the next).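

With the group on the amide-type nitrogen in a ring changed to 1-methylpiperidin-4-yl in place of oxan-4-yl, this assay shows a 16-fold lower number from compound 3 to compound 4 (1.20 log units; beyond the scatter), a large step, whereas the earlier exchange at this position, a 7.0-fold higher number from compound 1 to compound 3 (0.85 log units; beyond the scatter), was modest and involved the unmethylated piperidin-4-yl. Within the data shown here, the methyl on the amine nitrogen in a ring, a site the earlier compounds did not vary, also moves the number beyond the scatter, with a 2.3-fold lower number from compound 1 to compound 4 (0.35 log units; beyond the scatter), so the substituent on that ring nitrogen matters in its own right and the lowest number so far belongs to the methylated ring. No measurement at hand accounts for either step.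

The compounds shown leave open whether the trend continues past methyl on that ring nitrogen, for example with an ethyl, isopropyl or acetyl group, and whether the ring nitrogen is needed at all, which a cyclohexyl group at the same position would test. Going by these compounds, it also remains open how an open-chain amine such as 2-(dimethylamino)ethyl would compare with the piperidine rings on the amide-type nitrogen.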